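The source may hold more compounds than are shown below. What is called first, only, known or untested is meant among the compounds shown, and "the series" means these compounds.

Compound 1 `CCCCCCCCCCCOC(=O)CCC(=O)N1CCN(CCCOc2cc3c(Nc4ccc(F)c(Cl)c4)ncnc3cc2OC)CC1`: 85.2%
Compound 2 `CCCCCCCCCCCCCCCCCOC(=O)CCC(=O)N1CCN(CCCOc2cc3c(Nc4ccc(F)c(Cl)c4)ncnc3cc2OC)CC1`: 97.2%

In a functional assay on A549 cells (Homo sapiens) for cytotoxicity, read by MTT assay, with a stated time of 24 h, tested at 20 uM (a higher number here means a weaker effect of the compound at the concentration tested, a lower number a stronger effect), compound 2 gives 97.2%, the higher of the two numbers; compound 1 gives 85.2%. Compound 3 `CCCCCCCCCCCCCCCCCCCOC(=O)CCC(=O)N1CCN(CCCOc2cc3c(Nc4ccc(F)c(Cl)c4)ncnc3cc2OC)CC1` differs from compound 2 by ethyl in place of hydrogen on a saturated chain carbon, ten or more bonds along the chain from an oxygen next to a carbonyl group. For the measured compounds named here, the one measured step that bears on this change is a number 12 percentage points higher from compound 1 to compound 2 (beyond the scatter), a longer extension of the same chain. For the smaller extension here the expectation is a small rise in this assay or none beyond the scatter, as compound 2 already reads high at 97.2%. For compound 3 the expected value is 99%, between 90% and 107%. The expected step is thus a number 1.8 percentage points higher from compound 2 to compound 3 (within the scatter).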

Compound 3, a percentage reported as activity, at one concentration (the size of the read-out at that concentration, not a potency): 94.8%
For compound 3 the middle estimate is 4.2 percentage points above the measured one, and the stated range covers the measured number.
By their numbers in this assay, from the lowest: compounds 1, 3 and 2 (each within the scatter of the next, the first and the last beyond it).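

In this assay, ethyl in place of hydrogen on a saturated chain carbon, ten or more bonds along the chain from an oxygen next to a carbonyl group, gives a number 2.4 percentage points lower from compound 2 to compound 3 (within the scatter) and so leaves the two compounds apart by no more than the scatter. Octyl at the same kind of carbon gives a number 9.6 percentage points higher from compound 1 to compound 3 (within the scatter) and is likewise no clear difference, although a number 12 percentage points higher from compound 1 to compound 2 (beyond the scatter) does lie beyond the scatter, so compound 3 does not carry that rise further. Nothing available explains these numbers.

Going by these compounds, whether a much shorter chain would give a stronger effect at this concentration stays open. So does the effect of an amine or a carboxylic acid at the end of the chain.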